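The source may hold more compounds than are shown below. What is called first, only, known or untested is meant among the compounds shown, and "the series" means these compounds.

Measured in a functional assay on HepG2 cells (Homo sapiens) for inhibition, read by MTT assay, with a stated time of 72 h; a higher number here means a weaker inhibitor, a lower number a stronger inhibitor:
compound 1 `N#Cc1ccc(-n2cc(COc3cccc(NC(=O)Nc4ccc(Cl)c(C(F)(F)F)c4)c3)nn2)cc1` gives 2980 nM
compound 2 `CCc1cccc(-n2cc(COc3cccc(NC(=O)Nc4ccc(Cl)c(C(F)(F)F)c4)c3)nn2)c1` gives 37900 nM
compound 3 `CC(C)c1ccc(-n2cc(COc3cccc(NC(=O)Nc4ccc(Cl)c(C(F)(F)F)c4)c3)nn2)cc1` gives 2470 nM

Compound 3 has the lowest number of the three, but its gap to compound 1 is within the scatter, so these two cannot be ranked against each other; only compound 2 stands clearly apart, as the step of a 15-fold lower number from compound 2 to compound 3 (1.19 log units; beyond the scatter) shows. Compound 4 `O=C(Nc1cccc(OCc2cn(-c3cccc(F)c3)nn2)c1)Nc1ccc(Cl)c(C(F)(F)F)c1` differs from compound 3 in one place: 3-fluorophenyl in place of 4-isopropylphenyl on an aromatic nitrogen. Among the measured compounds shown here, two measured steps bear on this change. The step of a 13-fold higher number from compound 1 to compound 2 (1.10 log units; beyond the scatter) and the step of a 15-fold lower number from compound 2 to compound 3 (1.19 log units; beyond the scatter) both show that the 3-ethylphenyl group of compound 2 gives a much higher number than either the 4-cyanophenyl of compound 1 or the 4-isopropylphenyl of compound 3. For the measured compounds named here, the 3-fluorophenyl group of compound 4 is closer in kind to the 3-ethylphenyl of compound 2 than to those two groups, though fluorine is not ethyl and no measured pair tells how that matters. Going by the values given here, compound 4 is therefore expected to give a higher number in this assay, a step of a 4.9-fold higher number from compound 3 to compound 4 (0.69 log units; beyond the scatter) beyond the scatter but likely smaller than the one seen for compound 2. The estimate for compound 4 is 12000 nM, with a range from 3000 nM to 45000 nM.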

Compound 4, half-maximal inhibitory concentration: 2120 nM
Compound 4: the middle estimate sits 5.7-fold (0.75 log units) above what was measured; measured number below the stated range.
By their numbers in this assay, from the lowest: compounds 4, 3 and 1 (each within the scatter of the next); then compound 2.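

In this assay, the steps of a 1.2-fold lower number from compound 3 to compound 4 (0.07 log units; within the scatter) and a 1.4-fold lower number from compound 1 to compound 4 (0.15 log units; within the scatter) place the 3-fluorophenyl group level with the 4-isopropylphenyl and 4-cyanophenyl groups on the aromatic nitrogen. The step of an 18-fold lower number from compound 2 to compound 4 (1.25 log units; beyond the scatter) then shows that the high number of compound 2 does not extend to every group at that place on the phenyl ring, since fluoro in place of ethyl on that aromatic carbon is enough to remove the gap. No measurement shown here explains why ethyl and fluoro part so widely.

On these data alone, whether a methyl, a methoxy or an amine on that aromatic carbon would fall with fluoro or with ethyl remains open. Also open, as far as these compounds go, is how a plain phenyl on the aromatic nitrogen would compare with these groups.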